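Swapping the group on the sulfur-bound chain carbon

The source may hold more compounds than are shown below. What is called first, only, known or untested is meant among the compounds shown, and "the series" means these compounds.

Compound 1 `CCCSc1nc2nc(C)cc(N3CC[C@@H](C)[C@@H](N(C)c4ncnc5[nH]ccc45)C3)n2n1`: 20900 nM
Compound 2 `Cc1cc(N2CC[C@@H](C)[C@@H](N(C)c3ncnc4[nH]ccc34)C2)n2nc(SCc3ccccc3Br)nc2n1`: 21300 nM

Both compounds were tested in a functional assay on HGC-27 cells (Homo sapiens) for inhibition, read by MTT assay, with a stated time of 72 h; a lower number here means a stronger inhibitor, a higher number a weaker inhibitor. Compound 1 gives 20900 nM, and compound 2 gives 21300 nM, so the two sit within the scatter of each other: a 1.0-fold higher number from compound 1 to compound 2 (0.01 log units; within the scatter). That step replaced ethyl with 2-bromophenyl on a saturated chain carbon bound to a sulfur without moving the number.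

Compound 3 `Cc1cc(N2CC[C@@H](C)[C@@H](N(C)c3ncnc4[nH]ccc34)C2)n2nc(SCCc3ccccc3)nc2n1` changes the same position again: benzyl in place of 2-bromophenyl on a saturated chain carbon bound to a sulfur. Among the compounds with values here, the only measured step at this position, from compound 1 to compound 2, is within the scatter, and benzyl and 2-bromophenyl are groups of matching size. The expectation for this assay is therefore no step beyond the scatter, a 1.0-fold lower number from compound 2 to compound 3 (0.01 log units; within the scatter). Compound 3 is estimated at 21000 nM, with a range from 9000 nM to 48000 nM.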

Compound 3, half-maximal inhibitory concentration: 11800 nM
The estimate for compound 3 lay 1.8-fold (0.25 log units) above the measured number, within the range that was stated.
By their numbers in this assay, from the lowest: compounds 3, 1 and 2 (each within the scatter of the next).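

In this assay, phenethylsulfanyl in place of (2-bromobenzyl)sulfanyl gives a 1.8-fold lower number from compound 2 to compound 3 (0.26 log units; within the scatter), while phenyl in place of methyl on a saturated chain carbon, two bonds along the chain from a sulfur, gives a 1.8-fold lower number from compound 1 to compound 3 (0.25 log units; within the scatter). This adds a second aromatic group and a second comparison with the methyl-ended chain of compound 1, and all three compounds remain within the scatter of one another, so the changes shown at this position have not yet produced a clear shift. No supporting evidence here bears on why the numbers stay so close.

The compounds shown leave open whether a group of a different kind on this chain, such as an amine or a carboxylic acid, would move the number beyond the scatter. They also leave open what a longer chain ending in phenyl would do.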